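Fluoro for chloro on a nitrophenyl ring

The source may hold more compounds than are shown below. What is called first, only, known or untested is meant among the compounds shown, and "the series" means these compounds.

Of the compounds shown here, two have numbers so far in a functional assay on DU-145 cells (Homo sapiens) for inhibition, read by trypan blue exclusion, with a stated time of 96 h; on this read-out higher numbers stand for weaker inhibition of growth and lower numbers for stronger inhibition of growth. Compound 1 (`O=C(O)c1ccc(C(=O)/C(=C\c2ccc(F)c([N+](=O)[O-])c2)SCc2ccc(Cl)cc2Cl)cc1`) gives 1000 nM here, and compound 2 (`O=C(O)c1ccc(C(=O)/C(=C\c2ccc(Cl)c([N+](=O)[O-])c2)SCc2ccc(F)cc2)cc1`) gives 1000 nM on the same read-out, so compound 2 stands level with compound 1. Compound 3 (`O=C(O)c1ccc(C(=O)/C(=C\c2ccc(F)c([N+](=O)[O-])c2)SCc2ccc(F)cc2)cc1`) differs from compound 2 in one place: fluoro in place of chloro on an aromatic carbon. In words, fluoro takes the place of chloro on an aromatic carbon, ortho to a nitro group, turning 4-chloro-3-nitrophenyl into 4-fluoro-3-nitrophenyl. For the measured compounds named here, no measured pair yet differs in only one place, so the data do not show how far such a swap moves the number in this assay. With nothing to point either way, the expected step of no change at the digits printed from compound 2 to compound 3 (within the scatter) stays within the usual scatter, with no direction favoured. The estimated value for compound 3 is 1000 nM, with an expected range from 400 nM to 2500 nM in this measurement.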

Compound 3, concentration for 50% growth inhibition: 1000 nM
Estimate against measurement, compound 3: no gap at the digits printed; the measured number falls inside the stated range.
By their numbers in this assay, from the lowest: compounds 1, 2 and 3 (each within the scatter of the next).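

Here, for the first time, a pair differs in only one place: in this assay, fluoro in place of chloro on an aromatic carbon, ortho to a nitro group, gives no change at the digits printed from compound 2 to compound 3 (within the scatter). A second one-place change, 4-fluorophenyl in place of 2,4-dichlorophenyl on a saturated chain carbon bound to a sulfur, gives no change at the digits printed from compound 1 to compound 3 (within the scatter), so in these three compounds neither change moves the number beyond the scatter. No supporting data accompany these results to say why the number holds steady.

The compounds shown leave open whether an amine or a methoxy group on that same aromatic carbon would shift the number. They also leave open what a longer chain on the sulfur would do.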